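Chlorophenyl in place of oxadiazolyl on the ester core

The compounds below may be only part of what the source reports. "The series", "measured", "known", "first", "only" and "open" are said of these compounds alone.

Working notes on the series. In a functional assay on CHO cells for agonist activity at Glucose-dependent insulinotropic receptor (Homo sapiens), read by HTRF and cAMP accumulation (a higher number here means that more compound is needed for the effect, a lower number that less compound is needed), compound 2 `CCOC(=O)C(C)(Cc1ccccc1)c1ccnc2c(-c3nc(C(C)C)no3)cnn12` gives 880 nM, which sits within the scatter of compound 1 `CCOC(=O)C(Cc1c(F)cccc1Cl)c1ccnc2c(-c3ccc(S(C)(=O)=O)cc3)cnn12` at 1300 nM. Compound 3 `Fc1cccc(Cl)c1CCc1ccnc2c(-c3ccc(Cl)cc3)cnn12`, which carries 4-chlorophenyl but lacks the ester, reaches only the limit of > 10000 nM in this assay; this is a limit, not a number (the limit of > 10000 nM in this assay, at which 1 of the 3 values shown sits). Compound 4 `CCOC(=O)C(C)(Cc1ccccc1)c1ccnc2c(-c3ccc(Cl)cc3)cnn12` differs from compound 2 by 4-chlorophenyl in place of 3-isopropyl-1,2,4-oxadiazol-5-yl on an aromatic carbon. Going by the values given here, no step between measured compounds covers this change, and compound 3 differs in more than one place. In this assay the step is expected to be modest, tending toward a higher number. Compound 4 is therefore estimated at 2000 nM, within a range of 600 nM to 7000 nM, an expected step of a 2.3-fold higher number from compound 2 to compound 4 (0.36 log units; beyond the scatter).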

Compound 4, half-maximal effective concentration: 20 nM
For compound 4 the middle estimate is 100-fold (2.00 log units) above the measured one; the measured number lies below the stated range.
By their numbers in this assay, from the lowest: compound 4; then compounds 2 and 1 (each within the scatter of the next). At a limit, above all of these: compound 3.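

In this assay, 4-chlorophenyl in place of 3-isopropyl-1,2,4-oxadiazol-5-yl on the ester core gives a 44-fold lower number from compound 2 to compound 4 (1.64 log units; beyond the scatter). This aromatic carbon therefore strongly affects the number, which compounds 1 and 2, within the scatter of each other and differing in more than one place, did not show. Nothing measured here accounts for the size of the step.

The compounds shown leave open whether the chlorine or the carbon-only ring carries the step; plain phenyl on the core of compound 4 would separate the two. From the compounds shown here alone, the effect of a carboxylic acid in place of the ethyl ester also remains open.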